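Phenyl in place of cyclopentyl on the hydrazine nitrogen

The compounds below may be only part of what the source reports. "The series", "measured", "known", "first", "only" and "open" are said of these compounds alone.

Compound 1, `CNNc1nnc(-c2ccccc2C)s1`, only a limit: > 100 mg/kg
Compound 2, `Cc1ccccc1-c1nnc(NNC2CCCC2)s1`, only a limit: > 100 mg/kg

In a functional assay on the whole organism with Mus musculus as the target, in the maximal electroshock model, with a stated time of 1 h (on this read-out lower numbers stand for an effect already at smaller amounts and higher numbers for an effect only at larger amounts of compound), compound 2 stands at a limit, not at a number. Compound 3, `Cc1ccccc1-c1nnc(NNc2ccccc2)s1`, differs from compound 2 by phenyl in place of cyclopentyl on an amine nitrogen. For the measured compounds named here, the one measured step, a step that the two limits leave unreadable from compound 1 to compound 2, gives no readable size because both of its ends sit at the limit of > 100 mg/kg in this assay, at which 2 of the 2 values shown sit. No direction can be drawn from it, and the change has no other measured parallel. Compound 3 is therefore expected near 150 mg/kg, between 50 mg/kg and 450 mg/kg, most probably again reported only as a limit. The step expected is a step that the limit leaves unreadable from compound 2 to compound 3.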

Compound 3, dose for half-maximal effect: > 100 mg/kg
Compound 3: a limit, no number (the forecaster's own chance of this, stated with the estimate: 70%); the middle value is on the limit's open side.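

For the compounds shown here, no step among compound 1, compound 2 and compound 3 can be read in this assay, because all three sit at one limit: the limit of > 100 mg/kg in this assay, at which 3 of the 3 values shown sit. The compounds shown leave open whether methyl, cyclopentyl and phenyl on an amine nitrogen differ in effect at all.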